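The source may report more compounds than this note shows. Statements on the series, on what has been measured and on what is new or still open speak of the compounds shown alone.

Measured compounds:
- compound 1 `CCN(CC)c1ccc2cc(C(=O)c3ccc(N4CCN(C(=O)CN5CCNCC5)CC4)cc3)oc2c1`: > 100000 nM
- compound 2 `CCN(CC)c1ccc2cc(C(=O)c3ccc(N4CCN(C(=O)CN5CCN(S(=O)(=O)c6ccc(C#N)cc6)CC5)CC4)cc3)oc2c1`: 44100 nM

In an ADME assay on L02 cells (Homo sapiens) for cytotoxicity, read by MTT assay, with a stated time of 48 h (on this read-out lower numbers stand for stronger inhibition and higher numbers for weaker inhibition), compound 1 gives > 100000 nM, which is a limit of the assay and not a number (the limit of > 100000 nM in this assay, at which 1 of the 2 values shown sits). Compound 2 gives 44100 nM. Going by the values given here, the one measured step, an at least 2.2-fold lower number from compound 1 to compound 2 (0.35 log units; beyond the scatter), is the only guide. Compound 3 `CCN(CC)c1ccc2cc(C(=O)c3ccc(N4CCN(C(=O)CN5CCN(Cc6ccc(C#N)cc6)CC5)CC4)cc3)oc2c1` differs from compound 1 by 4-cyanobenzyl in place of hydrogen on an amine nitrogen in a ring. As compound 2 also carries a 4-cyanophenyl group on that ring nitrogen, a step of similar size and direction is expected, namely an at least 2.0-fold lower number from compound 1 to compound 3 (0.30 log units; that floor lies within the scatter). Compound 3 is therefore estimated at 50000 nM, within a range of 15000 nM to 150000 nM.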

Compound 3, half-maximal inhibitory concentration: 29600 nM
Estimate against measurement, compound 3: 1.7-fold (0.23 log units) above, within the range that was stated.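

In this assay there is an at least 3.3-fold lower number from compound 1 to compound 3 (0.52 log units; beyond the scatter) on placing 4-cyanobenzyl on this amine nitrogen in a ring, so the lower number does not depend on a sulfonyl link. Exchanging the two groups on that nitrogen gives a 1.5-fold lower number from compound 2 to compound 3 (0.17 log units; within the scatter) and does not tell them apart. Compound 1 stands at a limit and not a number, so its steps are floors only: the limit of > 100000 nM in this assay, at which 1 of the 3 values shown sits.

Going by these compounds, whether the nitrile matters stays open, as does what a plain benzyl, a methyl or an acetyl group on this nitrogen would give.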